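A Methoxyphenyl in Place of Difluorophenyl

The source may hold more compounds than are shown below. What is called first, only, known or untested is meant among the compounds shown, and "the series" means these compounds.

Compound 2 `O=C(COc1ccc(C(=O)/C=C/c2ccc(F)c(F)c2)cc1)N[C@H]1CCOC1=O` gives, in a functional assay on MGC-803 cells (Homo sapiens) for antiproliferative activity, read by MTT assay, with a stated time of 72 h (on this read-out higher numbers stand for weaker inhibition and lower numbers for stronger inhibition), a value that is only a limit of the assay, > 64000 nM. Compound 1 `O=C(COc1ccc(C(=O)/C=C/c2ccc(Cl)cc2Cl)cc1)N[C@H]1CCOC1=O` gives 26500 nM in this assay. Among the measured compounds shown here, the one measured step, an at least 2.4-fold higher number from compound 1 to compound 2 (0.38 log units; beyond the scatter), went toward weaker inhibition. Compound 3 `COc1ccccc1/C=C/C(=O)c1ccc(OCC(=O)N[C@H]2CCOC2=O)cc1` differs from compound 2 by 2-methoxyphenyl in place of 3,4-difluorophenyl on a double-bonded chain carbon bound to a double-bonded chain carbon. For the measured compounds named here, no measured step covers a 2-methoxyphenyl, so that earlier step is only a loose guide: changing the ring on this carbon once moved the number beyond the scatter. Compound 3 is expected to sit near the limit, with an at least 1.6-fold lower number from compound 2 to compound 3 (0.20 log units; that floor lies within the scatter) estimated as modest. Compound 3 is estimated at 40000 nM, ranging from 10000 nM to 120000 nM.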

Compound 3, half-maximal inhibitory concentration: 39400 nM
Estimate against measurement, compound 3: 1.0-fold (0.01 log units) above, and the stated range covers the measured number.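

Replacing 2,4-dichlorophenyl with 2-methoxyphenyl on this carbon gives a 1.5-fold higher number from compound 1 to compound 3 (0.17 log units; within the scatter), so in this assay these two rings cannot be told apart, and a ring without halogen gives a measurable number. Replacing 3,4-difluorophenyl with 2-methoxyphenyl gives an at least 1.6-fold lower number from compound 2 to compound 3 (0.21 log units; that floor lies within the scatter). That step has only a floor because compound 2 stands at a limit of the assay: the limit of > 64000 nM in this assay, at which 1 of the 3 values shown sits.

From the compounds shown here alone, the true number of compound 2 stays open. So does the effect on this ring of an amine or a carboxylic acid.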